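The source may hold more compounds than are shown below. What is called first, only, known or untested is meant among the compounds shown, and "the series" means these compounds.

Working notes on the series. The reference point is compound 1 `NS(=O)(=O)c1ccc(Nc2ncc(F)c(Nc3nc4ccccc4s3)n2)cc1`. In a functional assay on PC-3 cells (Homo sapiens) for antiproliferative activity, read by MTT assay, with a stated time of 48 h (on this read-out higher numbers stand for weaker inhibition and lower numbers for stronger inhibition), compound 1 gives only a limit, > 50000 nM. Compound 2 `Cc1cnc(Nc2ccc(Cl)cc2)nc1Nc1nc2ccccc2s1` likewise gives only a limit in this assay, > 50000 nM. For the measured compounds named here, compound 3 `NS(=O)(=O)c1ccc(Nc2nccc(Nc3nc4ccc(F)cc4s3)n2)cc1` is the one member with a numerical value in this assay, at 920 nM. Compound 1 therefore sits at the limit of > 50000 nM in this assay, at which 2 of the 3 values shown sit, together with compound 2, while compound 3 stands apart from both. The step under consideration leads to compound 4 `CS(=O)(=O)c1ccc(Nc2ncc(F)c(Nc3nc4ccccc4s3)n2)cc1`, differing from compound 1 by methyl in place of amino on a sulfonyl sulfur. Going by the values given here, no measured step exists for this change, so the expected step that the limit leaves unreadable from compound 1 to compound 4 is taken as none beyond the scatter, with direction unknown. Compound 4 is thus estimated at 60000 nM, in the range 10000 nM to 200000 nM.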

Compound 4, half-maximal inhibitory concentration: 2830 nM
Beside the measured number, compound 4's estimate is 21-fold (1.33 log units) above it; measured number below the stated range.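

In this assay, for the compounds shown here, methyl in place of amino on a sulfonyl sulfur gives an at least 17-fold lower number from compound 1 to compound 4 (1.24 log units; beyond the scatter), the first one-place step and one that shows this position is not silent. The change alone brings the core of compound 1 from a limit to a numerical value. On these data alone, the true size of the step stays unknown because compound 1 gives only a limit: the limit of > 50000 nM in this assay, at which 2 of the 4 values shown sit.

As far as these compounds go, how a longer chain such as ethyl, or a methylamino group, would read on the same sulfur remains open. So does whether the step depends on methyl entering or on amino leaving.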